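Working notes: from compound 2 to compound 4

This account rests on a few compounds, and the source may have more. Where it says the series, first, only, none or still open, it means among the compounds named here.

Measured in a functional assay on HeLa cells (Homo sapiens) for inhibition, read by CCK-8 assay, with a stated time of 48 h; on this read-out lower numbers stand for stronger inhibition and higher numbers for weaker inhibition:
- compound 1 `Cc1ccc(-c2ccsc2S(=O)(=O)NCCNC(=O)Nc2cc(C(F)(F)F)cc(C(F)(F)F)c2)c(Oc2ccc(O)c(O)c2)c1`: 9700 nM
- compound 2 `COc1ccc(NC(=O)NCCNS(=O)(=O)c2sccc2-c2ccc(C)cc2Oc2ccc(O)c(O)c2)cc1`: > 20000 nM (a limit)
- compound 3 `CC(C)c1ccc(Oc2ccc(O)c(O)c2)c(-c2ccsc2S(=O)(=O)NCCNC(=S)Nc2ccc([N+](=O)[O-])cc2)c1`: > 20000 nM (a limit)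

Compound 2 gives no number, only the limit > 20000 nM in this assay. It shares this position with compound 3, and the limit of > 20000 nM in this assay, at which 2 of the 3 values shown sit, mark the upper edge of what the set shows. Among the measured compounds shown here, compound 1 is the only member with a number, at 9700 nM in this assay.

The next compound to be measured is compound 4 `Cc1ccc(-c2ccsc2S(=O)(=O)NCCNC(=O)Nc2cc(Cl)cc(Cl)c2)c(Oc2ccc(O)c(O)c2)c1`. It carries 3,5-dichlorophenyl in place of 4-methoxyphenyl on an amide-type nitrogen, and the rest of the structure is the same: 3,5-dichlorophenyl in place of 4-methoxyphenyl on an amide-type nitrogen is the whole difference.

For the measured compounds named here, no measured pair in the set shows what a change at this place does, so the expectation is a loose one. It rests on compound 1 at 9700 nM as the single numeric anchor. Going by these compounds, the expected direction is towards stronger inhibition, with the estimated step of an at least 1.8-fold lower number from compound 2 to compound 4 (0.25 log units; that floor lies within the scatter) as a rough figure, and its true size stays open while the starting point is only a limit. For compound 4 the estimated value is 11000 nM, with an expected range from 4500 nM to 22000 nM and a real chance that only a limit is reported.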

Compound 4, half-maximal inhibitory concentration: 6500 nM
Beside the measured number, compound 4's estimate is 1.7-fold (0.23 log units) above it; the measured number falls inside the stated range.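

The place on the amide-type nitrogen now has a readable response: in this assay, 3,5-dichlorophenyl in place of 4-methoxyphenyl gives an at least 3.0-fold lower number from compound 2 to compound 4 (0.48 log units; beyond the scatter), so a change of this aryl group alone moves the read-out beyond the scatter. With the rest of the structure kept, compound 1, which carries trifluoromethyl groups where the chlorines stand, gives 9700 nM and compound 4 gives 6500 nM, and these two values support no order between the two groups. Compound 2 remains a limit and not a number, so the step is only a floor and its true size stays unknown: the limit of > 20000 nM in this assay, at which 2 of the 4 values shown sit.

The compounds shown do not tell whether the gain belongs to the arrival of the chlorines or the departure of the methoxy group, and a single chlorine, an amine or a carboxylic acid on this aryl ring would help to separate the two. Also open is whether the 3,5-dichlorophenyl result carries over to a thiourea in place of the urea or to a longer chain in the linker, since no pair shown tests either change.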